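Swapping Phenoxy for Dimethylamino on a Weak Growth Inhibitor

The source may report more compounds than this note shows. Statements on the series, on what has been measured and on what is new or still open speak of the compounds shown alone.

Measured compounds:
compound 1 `COc1cc(C)cc(-c2nn(CC#N)cc2-c2ccc(-c3cccc(C(C)=O)c3)nc2)c1`: 33900 nM
compound 2 `Cc1cc(O)cc(-c2nn(CC#N)cc2-c2ccnc(-c3ccc(Oc4ccccc4)cc3)c2)c1`: 19200 nM

In a functional assay on OVCAR-5 cells (Homo sapiens) for inhibition, read by sulforhodamine B assay, with a stated time of 48 h (a higher number here means a weaker inhibitor of growth, a lower number a stronger inhibitor of growth), compound 1 gives 33900 nM and compound 2 gives 19200 nM. Compound 2 has the lower of the two numbers, but its gap to compound 1 lies within the scatter, so neither stands apart. Compound 3 `Cc1cc(O)cc(-c2nn(CC#N)cc2-c2ccnc(-c3ccc(N(C)C)cc3)c2)c1` differs from compound 2 in one place: dimethylamino in place of phenoxy on an aromatic carbon. Going by the values given here, no measured pair shows what this change does, so no move beyond the scatter is expected in either direction. The estimate means an expected 1.0-fold higher number from compound 2 to compound 3 (0.02 log units; within the scatter) that stays within the scatter. For compound 3 the expected value in this assay is 20000 nM, with a range from 6000 nM to 60000 nM.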

Compound 3, concentration for total growth inhibition: 60400 nM
Estimate against measurement, compound 3: 3.0-fold (0.48 log units) below; the whole stated range lies below it.
By their numbers in this assay, from the lowest: compounds 2, 1 and 3 (each within the scatter of the next, the first and the last beyond it).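

In this assay putting dimethylamino in place of phenoxy on an aromatic carbon gives a 3.1-fold higher number from compound 2 to compound 3 (0.50 log units; beyond the scatter) and so a weaker inhibitor of growth. This single-place comparison shows that the group at this position affects the read-out, though the step is modest and rests on one pair. Nothing available explains why this change weakens growth inhibition.

As far as these compounds go, whether methoxy or a primary amine at this position would read closer to compound 2 or to compound 3 remains open. So does whether the same step would appear on a different core.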